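Oxime ether series: trimming the aryl on the fused core

A few compounds are considered here, and "the series" means these few. Any claim that something is new, unique, unknown or untested is made for them only; others in the source may bear on it.

Compound 3 `CC(C)c1ccc(-c2nc3sccn3c2/C=N/OCc2ccc(Cl)c(Cl)c2)cc1` gives 590 nM in an assay on HepG2 cells for agonist activity at nuclear receptor subfamily 1 group I member 3 (Homo sapiens), read by a luciferase reporter, with a stated time of 23 h (on this read-out lower numbers stand for an effect already at smaller amounts and higher numbers for an effect only at larger amounts of compound), the higher of the two numbers recorded so far; the nearest is compound 2 `Clc1ccc(-c2nc3occn3c2/C=N/OCc2ccc(Cl)c(Cl)c2)cc1`, which gives 410 nM, a gap within the usual scatter, so no order between the two can be read. Compound 1 `Clc1ccc(CO/N=C/c2c(-c3ccc(-c4ccccc4)cc3)nc3sccn23)cc1Cl` is reported as "not active" (no number reported), with no number attached. The next step strips a large group from the shared core down to a short chain: compound 4 `CCc1nc2sccn2c1/C=N/OCc1ccc(Cl)c(Cl)c1` differs from compound 3 by ethyl in place of 4-isopropylphenyl on an aromatic carbon. Going by the values given here, no measured pair shows this change. The expectation is a step toward larger numbers, beyond the scatter, of a 5.9-fold higher number from compound 3 to compound 4 (0.77 log units; beyond the scatter), given that compound 3 holds 590 nM with the 4-isopropylphenyl in place. Compound 4 is estimated at 3500 nM, with a range from 900 nM to 15000 nM.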

Compound 4, half-maximal effective concentration: 2600 nM
Compound 4: the middle estimate sits 1.3-fold (0.13 log units) above what was measured; the measured number falls inside the stated range.
By their numbers in this assay, from the lowest: compounds 2 and 3 (each within the scatter of the next); then compound 4.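

Ethyl in place of 4-isopropylphenyl on this aromatic carbon gives the first single-change step in the series, a 4.4-fold higher number from compound 3 to compound 4 (0.64 log units; beyond the scatter). Compound 4 still gives a number without a ring at this position, so the six-membered aromatic ring is not required for a measured effect, although the step lies beyond the scatter. Nothing at hand accounts for the size of this step.

A plain phenyl, a longer chain such as butyl, or an amine at this carbon would show whether the number follows the ring or the group's size. On these data alone, the same change on the core of compound 2 also remains open.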